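The source may report more compounds than this note shows. Statements on the series, on what has been measured and on what is new or still open speak of the compounds shown alone.

Compound 1 `CC1(C)C=C(n2ccccc2=O)c2cc(C(=O)c3ccccc3)ccc2O1` gives 6.61 in a functional assay (aorta) with Rattus norvegicus as the target; a lower number here means a less potent compound, a higher number a more potent compound, by a factor of ten per unit of this negative logarithm. Compound 2 `CC1(C)C=C(n2ccccc2=O)c2cc(C(=N)NO)ccc2O1` differs from compound 1 by a group of 4 heavy atoms (1 carbon, 2 nitrogen, 1 oxygen; no ring) in place of a group of 8 heavy atoms (7 carbon, 1 oxygen; one six-membered aromatic ring of carbon only), on an aromatic carbon. In this assay compound 2 gives 5.99; the step was a number 0.62 log units lower from compound 1 to compound 2 (beyond the scatter). Within the data shown here, compound 2 therefore stands lowest of the two values shown, with compound 1 as its only neighbour.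

Compound 3 `CC1(C)C=C(n2ccccc2=O)c2cc(C=O)ccc2O1` is not yet measured. It differs from compound 2 as follows: a group of 2 heavy atoms (1 carbon, 1 oxygen; no ring) in place of a group of 4 heavy atoms (1 carbon, 2 nitrogen, 1 oxygen; no ring), on an aromatic carbon. Among the measured compounds shown here, the only measured step that bears on this change is the one from compound 1 to compound 2, in which the same group of 4 heavy atoms entered on that aromatic carbon and the value fell modestly. Its removal in favour of formyl, a smaller group, is expected to recover part of that loss, giving an expected step of a number 0.21 log units higher from compound 2 to compound 3 (within the scatter). The estimate for compound 3 in this assay is 6.2, within a range from 5.6 to 6.8.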

Compound 3, logarithm of the reciprocal of the active concentration, log(1/C): 6.91
For compound 3 the middle estimate is 0.71 log units below the measured one; the measured number lies above the stated range.
By their numbers in this assay, from the lowest: compound 2; then compounds 1 and 3 (each within the scatter of the next).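

In this assay, the change to formyl gave a number 0.92 log units higher from compound 2 to compound 3 (beyond the scatter) and so reversed the earlier fall at this aromatic carbon, leaving compound 2 as the least potent of the three. Setting hydrogen in place of phenyl on the carbonyl carbon gave a number 0.30 log units higher from compound 1 to compound 3 (within the scatter) and so left the number within the scatter, which shows that the phenyl ring of compound 1 is not needed to hold the value in this assay. Compounds 1 and 3 both carry a carbonyl on this aromatic carbon, whereas compound 2 carries the group of four heavy atoms with its three hydrogen-bond donors, so a small size alone does not set the value, as compound 2 is smaller than compound 1 yet gives the lower number.

Nothing measured here accounts for the difference between these groups. On these data alone, whether the carbonyl itself matters stays open, and a nitrile, a carboxylic acid or an acetyl group on the same aromatic carbon would show whether other groups hold the value of compounds 1 and 3 or fall towards that of compound 2.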